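A Shared Chlorine Shift Across Two Sulfonate Cores

The compounds below may be only part of what the source reports. "The series", "measured", "known", "first", "only" and "open" are said of these compounds alone.

Compound 1 `COc1ccccc1OS(=O)(=O)/C=C/c1ccccc1Cl` and compound 2 `COc1cccc(OS(=O)(=O)/C=C/c2ccccc2Cl)c1` carry the same chain on different cores; the difference between the two cores is not broken down here. In an assay on U2OS cells for activation of nuclear factor erythroid 2-related factor 2 (Homo sapiens), read by chemiluminescence, with a stated time of 6 h (on this read-out higher numbers stand for an effect only at larger amounts of compound and lower numbers for an effect already at smaller amounts), compound 1 gives 76 nM, and in this assay compound 2 gives 165 nM. Compound 3 `COc1ccccc1OS(=O)(=O)/C=C/c1cccc(Cl)c1` differs from compound 1 by 3-chlorophenyl in place of 2-chlorophenyl on a double-bonded chain carbon bound to a double-bonded chain carbon, and in this assay compound 3 gives 698 nM, a step of a 9.2-fold higher number from compound 1 to compound 3 (0.96 log units; beyond the scatter). Compound 4 `COc1cccc(OS(=O)(=O)/C=C/c2cccc(Cl)c2)c1` has not been measured; it differs from compound 2 by 3-chlorophenyl in place of 2-chlorophenyl on a double-bonded chain carbon bound to a double-bonded chain carbon, the same change seen twice among these compounds. Because the step of a 9.2-fold higher number from compound 1 to compound 3 (0.96 log units; beyond the scatter) carries this same change, compound 4 is expected to show an 8.5-fold higher number from compound 2 to compound 4 (0.93 log units; beyond the scatter). This expectation rests on a single measured pair and is held loosely. Compound 4 is estimated at 1400 nM, within 500 nM to 4000 nM.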

Compound 4, half-maximal effective concentration: 943 nM
The estimate for compound 4 lay 1.5-fold (0.17 log units) above the measured number; the measured number falls inside the stated range.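

In this assay, 3-chlorophenyl in place of 2-chlorophenyl on the second core gave a 5.7-fold higher number from compound 2 to compound 4 (0.76 log units; beyond the scatter), the same direction as on the first core. The size of the change carried from one core to the other without a difference that can be told apart: the same change on two cores in this assay, a 9.2-fold higher number (0.96 log units; beyond the scatter) from compound 1 to compound 3 and a 5.7-fold higher number (0.76 log units; beyond the scatter) from compound 2 to compound 4, 1.6-fold (0.21 log units) apart, within the scatter of two such steps. Among these compounds, these are only two pairs on two cores, so they do not show that the change would hold on any further core, nor do they explain why the two chlorophenyl groups differ.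

The compounds shown leave open whether 4-chlorophenyl would follow the same course on both cores. From the compounds shown here alone, it also remains open whether an unsubstituted phenyl or an aminophenyl group would keep the two cores in step.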